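This account rests on a few compounds, and the source may have more. Where it says the series, first, only, none or still open, it means among the compounds named here.

Compound 1 `COc1ccc(/C=C/C(=O)/C=C/c2ccc(OCc3cn(CCCCCOc4cc(=O)oc5ccccc45)nn3)c(OC)c2)cc1OC`: 43%
Compound 2 `COc1cc(/C=C/C(=O)/C=C/c2cccs2)ccc1OCc1cn(CCOc2cc(=O)oc3ccccc23)nn1`: 66%
Compound 3 `COc1cc(/C=C/C(=O)/C=C/c2ccccc2)ccc1OCc1cn(CCCCOc2cc(=O)oc3ccccc23)nn1`: 31%

In a functional assay on COLO 205 cells (Homo sapiens) for inhibition, read by sulforhodamine B assay, with a stated time of 48 h, tested at 50 uM (a lower number here means less inhibition of growth, a higher number more inhibition of growth at the concentration tested), compound 2 stands highest of the three at 66%, beyond the scatter from the other two. Compound 4 `COc1cc(/C=C/C(=O)/C=C/c2cc(OC)c(OC)c(OC)c2)ccc1OCc1cn(CCOc2cc(=O)oc3ccccc23)nn1` has 3,4,5-trimethoxyphenyl in place of thiophen-2-yl on a double-bonded chain carbon bound to a double-bonded chain carbon. For the measured compounds named here, no measured pair isolates this change. Compound 1 at 43% and compound 3 at 31% also lack thiophen-2-yl, but each differs from compound 2 elsewhere too, so they offer only weak guidance. A fall is expected in this assay, with the estimated step of a number 16 percentage points lower from compound 2 to compound 4 (beyond the scatter) moderate and uncertain. For compound 4 the estimated value is 50%, with an expected range of 30% to 70%.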

Compound 4, percent growth inhibition at one concentration: 86%
Estimate against measurement, compound 4: 36 percentage points below; measured number outside the range, above it.
By their numbers in this assay, from the lowest: compound 3; then compound 1; then compound 2; then compound 4.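

In this assay, for the compounds shown here, the swap to 3,4,5-trimethoxyphenyl on this double-bonded chain carbon gives a number 20 percentage points higher from compound 2 to compound 4 (beyond the scatter) and is the first change read in one place alone. This position therefore accepts the trimethoxylated six-membered ring in place of thiophen-2-yl without loss of growth inhibition. No measurement at hand explains the rise.

From the compounds shown here alone, whether a single methoxy, a dimethylamino group or a carboxylic acid on that ring would keep the gain remains open. So does whether the step carries over to the chains of compound 1 and compound 3.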